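Hydroxyphenyl for Fluorophenyl on the Amide Nitrogen

A few compounds are considered here, and "the series" means these few. Any claim that something is new, unique, unknown or untested is made for them only; others in the source may bear on it.

Measured in a functional assay on SiHa cells (Homo sapiens) for inhibition, read by CCK-8 assay, with a stated time of 72 h, tested at 10 uM; a lower number here means less inhibition of growth, a higher number more inhibition of growth at the concentration tested:
compound 1 `CN(C)C(=O)c1cc2cnc(Nc3ccc(N)cn3)nc2n1C1CCCC1` gives 61.5%
compound 2 `CN(C)C(=O)c1cc2cnc(Nc3ccc(NC(=O)C4(C(=O)Nc5ccccc5F)CC4)cc3)nc2n1C1CCCC1` gives 103%
compound 3 `Cc1ccc(NC(=O)C2(C(=O)Nc3ccc(Nc4ncc5cc(C(=O)N(C)C)n(C6CCCC6)c5n4)cc3)CC2)cc1` gives 104%

Compound 2 stands second highest of the three numbers. Its nearest neighbour is compound 3, whose number lies within the scatter of it, so the two cannot be told apart. Compound 1, which carries only a small amino-substituted ring where the other two carry the long diamide chain, sits far lower, a gap beyond the scatter.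

Compound 4 `CN(C)C(=O)c1cc2cnc(Nc3ccc(NC(=O)C4(C(=O)Nc5ccc(O)cc5)CC4)cc3)nc2n1C1CCCC1` differs from compound 2 in one place: 4-hydroxyphenyl in place of 2-fluorophenyl on an amide-type nitrogen.

Going by the values given here, one measured step bears on this change, since it alters the ring on the same amide-type nitrogen: a number 1 percentage points higher from compound 2 to compound 3 (within the scatter). Replacing 2-fluorophenyl by 4-methylphenyl there left the number essentially unchanged, and both compounds lie near complete inhibition of growth at the concentration tested. Among the compounds with values here, with only that one step to draw on, and no measured example of a 4-hydroxyphenyl ring at this position, the expectation is that the change from compound 2 to compound 4 again stays within the scatter, giving an estimated step of a number 3 percentage points lower from compound 2 to compound 4 (within the scatter).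

For compound 4 the estimate in this assay is therefore 100%, with a range from 86% to 110%.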

Compound 4, percent growth inhibition at one concentration: 94.3%
The estimate for compound 4 lay 5.7 percentage points above the measured number; low and high end bracket the measured number.
By their numbers in this assay, from the lowest: compound 1; then compounds 4, 2 and 3 (each within the scatter of the next).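

In this assay, the step of a number 8.7 percentage points lower from compound 2 to compound 4 (within the scatter) shows that 4-hydroxyphenyl, with 1 hydrogen-bond donor and 1 hydrogen-bond acceptor, can stand on the amide-type nitrogen where 2-fluorophenyl has neither, without a change that can be told from the scatter. The closer comparison with the methyl-bearing ring, where hydroxy replaces methyl on an aromatic carbon, gives a number 9.7 percentage points lower from compound 3 to compound 4 (within the scatter) and is also within the scatter, so this swap of a single group leaves no readable mark either. Going by these compounds alone, the earlier pair covered only two rings without a hydrogen-bond donor, whereas these three compounds now show that 2-fluorophenyl, 4-methylphenyl and 4-hydroxyphenyl cannot be told apart at this position at the one concentration tested.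

Nothing available here explains why these rings read alike. Still open, on these data alone, is how a ring carrying an amine or a carboxylic acid, or a longer chain in place of the ring, would read on this nitrogen, and whether compounds 2, 3 and 4 would separate if tested at lower concentrations.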